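The compounds below may be only part of what the source reports. "The series", "measured", "known", "first", "only" and "open" are said of these compounds alone.

Working notes on the series. Compound 2 `CC(C)(C)CCc1cnc(CCc2ccc(-c3ccccc3C(=O)O)cc2)[nH]1` is the stronger of the two compounds measured in an in vitro functional assay on cells for agonist activity at Bombesin receptor subtype-3 (Homo sapiens), read by luminescence and calcium flux (on this read-out higher numbers stand for an effect only at larger amounts of compound and lower numbers for an effect already at smaller amounts), where compound 2 gives 39 nM. Among the compounds with values here, its only neighbour is compound 1 `N#Cc1cccc(Cc2cnc(CCc3ccc(-c4ccccc4C(=O)O)cc3)[nH]2)c1`, which in this assay gives 812 nM; the single step so far, a 21-fold lower number from compound 1 to compound 2 (1.32 log units; beyond the scatter), replaces 3-cyanophenyl with neopentyl on the saturated chain carbon bound to an aromatic carbon and is large. Compound 3 `O=C(O)c1ccccc1-c1ccc(CCc2ncc(CC3CCCCCC3)[nH]2)cc1` is the next member, not yet measured. Its change from compound 2 is cycloheptyl in place of neopentyl on a saturated chain carbon bound to an aromatic carbon; cut one bond further out, 3,3-dimethylbutyl becomes cycloheptylmethyl. Within the data shown here, no measured step compares one saturated carbon group with another at this place, so the only guidance is that compound 2 already carries a saturated group there and sits at the low end, with a 21-fold lower number from compound 1 to compound 2 (1.32 log units; beyond the scatter) marking the move away from the aromatic group. The expected step is therefore small, within or near the scatter, as a 1.3-fold lower number from compound 2 to compound 3 (0.11 log units; within the scatter). Compound 3 is estimated at 30 nM, with a range of 10 nM to 90 nM.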

Compound 3, half-maximal effective concentration: 88 nM
Estimate against measurement, compound 3: 2.9-fold (0.47 log units) below; low and high end bracket the measured number.
By their numbers in this assay, from the lowest: compound 2; then compound 3; then compound 1.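

In this assay, within the data shown here, the step of a 2.3-fold higher number from compound 2 to compound 3 (0.35 log units; beyond the scatter) is the first comparison of two saturated carbon groups on a saturated chain carbon bound to an aromatic carbon, and it shows that the number still responds to which saturated group sits there, with the open-chain neopentyl giving the lower number of the pair. Cycloheptyl nonetheless gives a 9.2-fold lower number from compound 1 to compound 3 (0.97 log units; beyond the scatter) so both saturated groups shown give lower numbers than 3-cyanophenyl, with no compound here going against that, although this step is printed as modest and a 21-fold lower number from compound 1 to compound 2 (1.32 log units; beyond the scatter) as large. No supporting measurement bears on either step, so the result remains an observation without an explanation.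

The change from neopentyl to cycloheptyl alters the ring and the heavy-atom count together, so the compounds shown do not separate one from the other. Also open, on these data alone, is how a cyclopentyl or cyclohexyl group would read at this place, and what an amine or a hydroxyl group on the saturated chain would do to the number.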